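This account rests on a few compounds, and the source may have more. Where it says the series, first, only, none or still open, it means among the compounds named here.

Compound 1 `COc1ccc(C2=NN(C(=O)CN3CCCCC3)C(c3ccccc3O)C2)cc1` was tested in an assay on isolated protein for inhibition of Amine oxidase [flavin-containing] A (Homo sapiens), read by fluorescence, with stated times of 15 min and 20 min (a higher number here means a weaker inhibitor, a lower number a stronger inhibitor), and gave 12700 nM. Among the two compounds measured so far it shows the highest number; its nearest neighbour is compound 2 `O=C(CN1CCCCC1)N1N=C(c2ccc(F)cc2)CC1c1ccccc1O`, which in this assay gives 8020 nM. Going by the values given here, the single measured step, a 1.6-fold lower number from compound 1 to compound 2 (0.20 log units; within the scatter), stays within the scatter, so these two compounds cannot be ordered on the numbers available.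

Compound 3 `COc1ccc(C2=NN(C(=O)CN3CCCCC3)C(c3cc(Cl)ccc3O)C2)cc1` differs from compound 1 in one place: chloro in place of hydrogen on an aromatic carbon. Among the compounds with values here, no measured pair shows a chloro introduced on the 2-hydroxyphenyl part of the shared core; the only step measured concerns the other aromatic ring, where a fluoro replaced a methoxy, and that step was small. The measured pairs therefore offer nothing that points to a change beyond the scatter in this assay in either direction. For compound 3 the expected step is a 1.4-fold lower number from compound 1 to compound 3 (0.15 log units; within the scatter). The estimate for compound 3 in this assay is 9000 nM, with a range from 3500 nM to 25000 nM.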

Compound 3, half-maximal inhibitory concentration: 9650 nM
For compound 3 the middle estimate is 1.1-fold (0.03 log units) below the measured one; low and high end bracket the measured number.
By their numbers in this assay, from the lowest: compounds 2, 3 and 1 (each within the scatter of the next).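

Adding chloro to the shared core, on the aromatic carbon para to the hydroxy group, gives the first measured look at the 2-hydroxyphenyl part, and in this assay the change to 5-chloro-2-hydroxyphenyl gives a 1.3-fold lower number from compound 1 to compound 3 (0.12 log units; within the scatter). Going by these compounds alone, on the core of compound 1, this position therefore takes a single chloro with no step that can be told apart from the scatter, so the measured result gives no sign that this substitution matters in this assay. No measurement available here bears on why the chloro leaves the result within the scatter.

From the compounds shown here alone, it remains open whether a different group at this same place, such as a bromo, a methoxy, an amine or a carboxylic acid, would give a step beyond the scatter, or whether a chloro on another carbon of this ring would do so. It is also open whether the chloro would read the same way with a fluoro on the other aromatic ring, as in compound 2, since the compounds shown include no such combination.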